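The source may report more compounds than this note shows. Statements on the series, on what has been measured and on what is new or still open speak of the compounds shown alone.

- compound 1 `CC1(COc2ccc(-c3ccc(F)cc3)cc2)CCn2cc([N+](=O)[O-])nc2O1` gives > 64000 nM as its reading
- compound 2 `O=[N+]([O-])c1cn2c(n1)OC(COc1ccc(-c3ccc(F)nc3F)cn1)CC2` gives > 64000 nM as its reading
- compound 3 `O=[N+]([O-])c1cn2c(n1)OC(COc1ncc(-c3ccc(F)cc3)cn1)CC2` gives > 64000 nM as its reading

All three readings come from an ADME assay on MRC5 cells (Homo sapiens) for cytotoxicity, read by resazurin assay, with a stated time of 72 h (on this read-out higher numbers stand for weaker inhibition and lower numbers for stronger inhibition), and this test measures harm to human cells, so a high reading means a mild effect. For compound 1 the reading of > 64000 nM is a limit, not a number. The same holds across the set, where the evidence is the limit of > 64000 nM in this assay, at which 3 of the 3 values shown sit, and so these compounds cannot be ranked against one another.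

Compound 4 `CC1(COc2ccc(-c3ccc(F)nc3)cc2)CCn2cc([N+](=O)[O-])nc2O1` has not yet been measured. It keeps the core of compound 1 and carries 6-fluoropyridin-3-yl in place of 4-fluorophenyl on an aromatic carbon and the rest of the molecule is untouched. The swap adds a nitrogen to an aromatic ring, and nitrogen in the aromatic rings is already present in compound 2. The reading of > 64000 nM for compound 2 is also a limit.

No step beyond the usual scatter is expected in this assay and no direction is favoured. The estimate for this swap is a number no higher from compound 1 to compound 4 (the limit leaves the size open) and it is expected to mean no real change. For compound 4 the expected value is 64000 nM with an estimated range from 30000 nM to 64000 nM and the test will most likely report only a limit.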

Compound 4, half-maximal inhibitory concentration: > 64000 nM
Compound 4 gave a limit, no number; the forecaster's own chance of this, stated with the estimate: 85%; the middle value lies on the limit itself.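

In this assay compound 4 gives > 64000 nM, which is a limit and not a number. Among the compounds shown here, no step from compound 1 to compound 4 can be read, because both readings are limits: the limit of > 64000 nM in this assay, at which 4 of the 4 values shown sit. The compounds shown leave open whether 6-fluoropyridin-3-yl in place of 4-fluorophenyl changes the harm to human cells at all.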